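The source may hold more compounds than are shown below. What is called first, only, known or untested is meant among the compounds shown, and "the series" means these compounds.

The measured compounds:
compound 1, `CCCn1nc(-c2cccnc2)c2ccccc2c1=O`, in a functional assay (trachea) with Cavia porcellus as the target (a higher number here means a weaker inhibitor, a lower number a stronger inhibitor), gives 3160 nM
compound 2, `CCCCn1nc(-c2cccnc2)c2ccccc2c1=O`, in this assay gives 2290 nM
compound 3, `CCn1nc(-c2cncs2)c2ccccc2c1=O`, in this assay gives 562 nM

Compound 1 and compound 2 share one core, while compound 3 carries another; how the two cores differ is not broken down here. In this assay compound 3 gives the lowest of the three numbers, and its gap to each of the others lies beyond the scatter. Between compound 1 and compound 2 the change is methyl in place of hydrogen on a saturated chain carbon, three bonds along the chain from an aromatic nitrogen, and it made a 1.4-fold lower number from compound 1 to compound 2 (0.14 log units; within the scatter).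

Compound 4, `CC(C)n1nc(-c2cncs2)c2ccccc2c1=O`, has not yet been measured. It differs from compound 3 by methyl in place of hydrogen on a saturated chain carbon bound to an aromatic nitrogen and a saturated chain carbon. This is the same kind of change, not the same one: in compound 2 the entering methyl sits on a saturated chain carbon three bonds along the chain from an aromatic nitrogen, whereas in compound 4 it sits on a saturated chain carbon bound to an aromatic nitrogen and a saturated chain carbon. Given that the earlier step of a 1.4-fold lower number from compound 1 to compound 2 (0.14 log units; within the scatter) stayed within the scatter, a step of similar size is expected here: a 1.1-fold lower number from compound 3 to compound 4 (0.05 log units; within the scatter). Compound 4 is therefore estimated at 500 nM in this assay, most likely between 200 nM and 1300 nM.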

Compound 4, half-maximal inhibitory concentration: 3390 nM
The estimate for compound 4 lay 6.8-fold (0.83 log units) below the measured number; the whole stated range lies below it.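

In this assay, methyl in place of hydrogen gave a 6.0-fold higher number from compound 3 to compound 4 (0.78 log units; beyond the scatter). Set beside the earlier methyl step, this shows that the effect of such a change cannot simply be carried from one core to the other in this series: the same change on two cores in this assay, a 1.4-fold lower number (0.14 log units; within the scatter) from compound 1 to compound 2 and a 6.0-fold higher number (0.78 log units; beyond the scatter) from compound 3 to compound 4, 8.3-fold (0.92 log units) apart, beyond the scatter of two such steps It does not show that the core alone decides the outcome, since the entering methyl also sits in a different place on the chain in each pair, and a single pair on each core cannot separate these two differences or give a reason for the gap.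

The compounds shown leave open how a propyl chain or a cyclopropyl ring would fare on the core of compound 3, and whether ethyl to isopropyl on the core of compound 1 would also give a higher number. On these data alone, how an amine or a hydroxyl group on the chain would behave on either core also remains open.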